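This account rests on a few compounds, and the source may have more. Where it says the series, first, only, none or still open, it means among the compounds named here.

Compound 1 `Cc1ccc(F)cc1N(C)C(=O)c1ccc(-c2ccc(O)cc2)o1` gives 2200 nM in an assay on cytosol from placenta for inhibition of 17-beta-hydroxysteroid dehydrogenase type 2 (Homo sapiens), read by HPLC, using microsomes, with a stated time of 10 min, in the presence of a further agent that is not named here; a higher number here means a weaker inhibitor, a lower number a stronger inhibitor.
Compound 2 `Cc1cc(F)ccc1N(C)C(=O)c1ccc(-c2ccc(O)cc2)o1` gives 1700 nM.
Compound 3 `Cc1cccnc1N(C)C(=O)c1ccc(-c2ccc(O)cc2)o1` gives > 10000 nM, which is a limit of the assay and not a number.

Compound 3 therefore stands only at the limit of > 10000 nM in this assay, at which 1 of the 3 values shown sits, with no number of its own. Compound 4 `Cc1ncccc1N(C)C(=O)c1ccc(-c2ccc(O)cc2)o1` differs from it in that (2-methylpyridin-3-yl in place of 3-methylpyridin-2-yl on an amide-type nitrogen). The measured steps that bear on this change are those into compound 3: an at least 4.5-fold higher number from compound 1 to compound 3 (0.65 log units; beyond the scatter) and an at least 5.8-fold higher number from compound 2 to compound 3 (0.76 log units; beyond the scatter), both showing that a methylpyridinyl group on the amide nitrogen gave a weaker inhibitor than either fluoro-methylphenyl group. The step of a 1.3-fold lower number from compound 1 to compound 2 (0.11 log units; within the scatter) shows that moving the fluorine within the phenyl ring changed little. Within the data shown here, no measured step moves the nitrogen within the pyridine ring, so the size of the step in this assay from compound 3 to compound 4 rests on no direct precedent; it is expected to stay close to where compound 3 sits, as a number no higher from compound 3 to compound 4 (the limit leaves the size open). Compound 4 is thus estimated at 10000 nM, within 3000 nM to 30000 nM.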

Compound 4, half-maximal inhibitory concentration: > 30000 nM
Compound 4: a limit, no number (the forecaster's own chance of this, stated with the estimate: 50%); middle value at least 3.0-fold (0.47 log units) away from the limit.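

In this assay compound 4 gives only a limit of the assay and not a number: the limit of > 30000 nM in this assay, at which 1 of the 4 values shown sits. With 2-methylpyridin-3-yl on the amide-type nitrogen, the inhibitor is again clearly weaker than with either fluoro-methylphenyl group, at an at least 17-fold higher number from compound 2 to compound 4 (1.24 log units; beyond the scatter) and an at least 13-fold higher number from compound 1 to compound 4 (1.13 log units; beyond the scatter), so among the compounds shown this weakening is not confined to 3-methylpyridin-2-yl. Compound 3 also gives only a limit, and the step from it to compound 4 cannot be read: the limit of > 10000 nM in this assay, at which 1 of the 4 values shown sits.

The compounds shown leave open how a plain 2-methylphenyl group on the amide-type nitrogen would read. They also leave open whether a pyridinyl group with an amine or a chlorine in place of the methyl would come back to the level of compound 1 and compound 2.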